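This account rests on a few compounds, and the source may have more. Where it says the series, first, only, none or still open, it means among the compounds named here.

Measured compounds:
Compound 1, `c1ccc(-c2noc(-c3ccncc3)n2)cc1`, gives 657000 nM.
Compound 2, `COc1ccc(-c2noc(-c3cccnc3)n2)cc1OC1CCCC1`, gives > 1000000 nM.
Compound 3, `COc1ccc(-c2noc(Cc3c[nH]c4ccccc34)n2)cc1OC1CCCC1`, gives > 1000000 nM.

The three compounds were tested in a functional assay on DU-145 cells (Homo sapiens) for antiproliferative activity, read by MTT assay, with a stated time of 24 h; a higher number here means a weaker inhibitor, a lower number a stronger inhibitor. Compound 1 gives a number, 657000 nM, that already marks it as a very weak inhibitor. Compound 2 does not give a number at all; its value of > 1000000 nM is a limit of the assay. Compound 3 likewise sits at a limit, > 1000000 nM. Thus two of the three values rest on (the limit of > 1000000 nM in this assay, at which 2 of the 3 values shown sit), and compound 2 stands at that limit, with no numerical reading of its own.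

The step from compound 2 to compound 4, `COc1ccc(-c2noc(C3CCCN3)n2)cc1OC1CCCC1`, is a single change on the shared core: pyrrolidin-2-yl in place of pyridin-3-yl on an aromatic carbon. Among the measured compounds shown here, no measured pair in this set differs in one place, so there is no measured step to lean on. Since compound 2 sits at the limit and compound 3 does too, no shift beyond the usual scatter is expected for an at least 1.1-fold lower number from compound 2 to compound 4 (0.04 log units; that floor lies within the scatter) in this assay. Compound 4 is therefore estimated at 900000 nM, within a range from 300000 nM to 2000000 nM, and it is expected that the assay may again report only a limit.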

Compound 4, half-maximal inhibitory concentration: 242000 nM
Compound 4: the middle estimate sits 3.7-fold (0.57 log units) above what was measured; measured number outside the range, below it.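

In this assay, pyrrolidin-2-yl in place of pyridin-3-yl gives an at least 4.1-fold lower number from compound 2 to compound 4 (0.61 log units; beyond the scatter), so this position of the shared core, on an aromatic carbon next to the ring nitrogen and next to the ring oxygen, is not indifferent to the group it carries. Among the compounds shown here, this is the only step between measured compounds that differ in one place, and it yields a reading where compound 2 has none, with compound 4 at 242000 nM. The size of the step can be given only as a floor because compound 2 has no number of its own: the limit of > 1000000 nM in this assay, at which 2 of the 4 values shown sit.

The single change replaces a six-membered aromatic ring with a five-membered non-aromatic ring and also brings in a hydrogen-bond donor, so the compounds shown leave open which of these differences goes with the lower number. They also leave open whether an open-chain amine such as aminomethyl, or a piperidin-2-yl ring, would give a similar number at this position on the shared core.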